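A few compounds are considered here, and "the series" means these few. Any claim that something is new, unique, unknown or untested is made for them only; others in the source may bear on it.

Of the compounds shown here, two of a shared core have been measured in a functional assay on SNB-75 cells (Homo sapiens) for inhibition, read by sulforhodamine B assay, with a stated time of 48 h; on this read-out higher numbers stand for weaker inhibition of growth and lower numbers for stronger inhibition of growth. Compound 1 `COc1cc2cc(Oc3ccc(NC(=O)Nc4cccc(C(F)(F)F)c4)cc3)c(C)nc2cc1OC` gives 1170 nM in this assay. Compound 2 `COc1cc2cc(Oc3ccc(NC(=O)Nc4ccc(Cl)c(C(F)(F)F)c4)cc3)c(C)nc2cc1OC`, which carries an added chloro group, gives 1030 nM in this assay. The step from compound 1 to compound 2 is a 1.1-fold lower number from compound 1 to compound 2 (0.06 log units; within the scatter), so the two numbers cannot be told apart; on the numbers shown, compound 2 simply stands beside compound 1.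

Compound 3 `COc1cc2cc(Oc3ccc(NC(=O)Nc4ccc(Cl)c(Cl)c4)cc3)c(C)nc2cc1OC` is not yet measured. It differs from compound 2 in one place: chloro in place of trifluoromethyl on an aromatic carbon. Among the measured compounds shown here, no measured step covers this exact swap of one small group for another on that ring; the only step available, from compound 1 to compound 2, changed the same ring and stayed within the scatter. On that basis, a step of a 1.1-fold higher number from compound 2 to compound 3 (0.03 log units; within the scatter) from compound 2 to compound 3 is expected, meaning no change beyond the scatter. In this assay compound 3 is therefore expected to give about 1100 nM, with a likely range from 500 nM to 2500 nM.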

Compound 3, concentration for 50% growth inhibition: 2330 nM
For compound 3 the middle estimate is 2.1-fold (0.33 log units) below the measured one; measured number inside the range.
By their numbers in this assay, from the lowest: compounds 2, 1 and 3 (each within the scatter of the next, the first and the last beyond it).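

In this assay, among the compounds shown here, replacing trifluoromethyl with chloro, ortho to a chloro group, gives a 2.3-fold higher number from compound 2 to compound 3 (0.35 log units; beyond the scatter) and is the first step in this small set to pass beyond the scatter, which shows that the number can respond to the choice of group at this position, although the effect is only modest. For the compounds shown here, the picture is not a clean separation of all three compounds, since the comparison that swaps 3-(trifluoromethyl)phenyl for 3,4-dichlorophenyl gives a 2.0-fold higher number from compound 1 to compound 3 (0.30 log units; within the scatter) and therefore does not distinguish those two compounds, so only the pair with the 4-chloro-3-(trifluoromethyl)phenyl group shows a real difference. No measurement at hand explains why growth inhibition shifts with this swap.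

As far as these compounds go, it remains open how other groups at this position, such as methoxy, nitrile or an amine, would compare with trifluoromethyl and chloro. From the compounds shown here alone, it is also open whether the same swap would give a step of similar size without the chloro group on that ring, or in cells other than those used here.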